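The source may hold more compounds than are shown below. What is called first, only, known or untested is meant among the compounds shown, and "the series" means these compounds.

Measured compounds:
compound 1, `O=C(Nc1ccc(-n2ncc3c(C(F)(F)F)cccc32)cc1)Nc1ccc(Cl)c(C(F)(F)F)c1`, 3000 nM
compound 2, `O=C(Nc1ccc(-n2ncc3c(Br)cccc32)cc1)Nc1ccc(Cl)c(C(F)(F)F)c1`, 1700 nM
compound 3, `COc1cccc2c1cnn2-c1ccc(NC(=O)Nc2ccc(Cl)c(C(F)(F)F)c2)cc1`, a limit, > 32000 nM

All three share one core and differ only in a single group on an aromatic ring. In a functional assay on LoVo cells (Homo sapiens) for cytotoxicity, read by MTT assay, with a stated time of 72 h (on this read-out lower numbers stand for stronger inhibition and higher numbers for weaker inhibition), compound 2 gives 1700 nM, the lowest of the two plain numbers shown. Compound 1 gives 3000 nM. The step of a 1.8-fold lower number from compound 1 to compound 2 (0.25 log units; within the scatter) is within the scatter, so these two cannot be ordered. Compound 3 reaches only > 32000 nM, which is a limit of the assay rather than a number. The steps of an at least 10-fold higher number from compound 1 to compound 3 (1.02 log units; beyond the scatter) and an at least 18-fold higher number from compound 2 to compound 3 (1.27 log units; beyond the scatter) are both large and point the same way.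

Compound 4 `O=C(Nc1ccc(-n2ncc3ccncc32)cc1)Nc1ccc(Cl)c(C(F)(F)F)c1` has not been measured. The change from compound 2 is a group of 9 heavy atoms (6 carbon, 3 nitrogen; one five-membered aromatic ring with 2 hetero atoms, one six-membered aromatic ring with 1 hetero atom) in place of a group of 10 heavy atoms (7 carbon, 2 nitrogen, 1 bromine; one five-membered aromatic ring with 2 hetero atoms, one six-membered aromatic ring of carbon only), on an aromatic carbon. The bromo group disappears in this change, and a ring nitrogen appears. The measured steps show that swapping bromo for methoxy gave an at least 18-fold higher number from compound 2 to compound 3 (1.27 log units; beyond the scatter), while swapping trifluoromethyl for bromo gave only a 1.8-fold lower number from compound 1 to compound 2 (0.25 log units; within the scatter). Compound 4 is therefore expected to give a higher number, estimated at 8000 nM with a range from 2500 nM to 32000 nM. For compound 4 this estimate means a step of a 4.7-fold higher number from compound 2 to compound 4 (0.67 log units; beyond the scatter) in this assay.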

Compound 4, half-maximal inhibitory concentration: 7100 nM
Beside the measured number, compound 4's estimate is 1.1-fold (0.05 log units) above it; the range from low to high includes it.
By their numbers in this assay, from the lowest: compounds 2 and 1 (each within the scatter of the next); then compound 4. At a limit, above all of these: compound 3.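

For the compounds shown here, the earlier compounds changed only a single group on the ring of the shared core, whereas compound 4 changes the ring itself: the bromo group leaves and a ring nitrogen enters, and in this assay this gives a modest step, a 4.2-fold higher number from compound 2 to compound 4 (0.62 log units; beyond the scatter). The bromo group is therefore not needed for a plain, readable number at this part of the molecule, although the number with the new ring is higher and so the inhibition is weaker. Compound 3, with methoxy in place of bromo, stands at > 32000 nM, which is a limit of the assay and not a number.

Two things change at once in compound 4, the loss of the bromo group and the gain of the ring nitrogen, so the compounds shown cannot separate their shares in the step, and no measurement here accounts for it. Also open, going by these compounds, is how the same core would read with an amine, a nitrile or a carboxylic acid in place of the bromo group, or with the bromo group kept alongside the ring nitrogen.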